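Swapping a Bromine Substituent for a Nitro Group

The compounds below may be only part of what the source reports. "The series", "measured", "known", "first", "only" and "open" are said of these compounds alone.

Compound 3 `COC(=O)c1ccc(NCc2cncn2Cc2ccc(Br)cc2)cc1-c1ccccc1` is one of three related compounds tested in a toxicity assay on NIH3T3 cells (Mus musculus) for cytotoxicity, read by resazurin assay; a lower number here means that less compound is needed, a higher number that more compound is needed for the effect. In this assay compound 3 gives > 10000 nM, which is a limit of the assay rather than a number. In this assay compound 2 `COC(=O)c1ccc(NCc2cncn2Cc2cccc(Cl)c2)cc1-c1ccccc1` gives > 10000 nM, likewise a limit. In this assay compound 1 `COC(=O)c1ccc(NCc2cncn2Cc2ccccc2OC)cc1-c1ccccc1` gives "not determined" (no result reported). Within the data shown here, the only measured step, a step that the two limits leave unreadable from compound 2 to compound 3, rests on two values sitting at the limit of > 10000 nM in this assay, at which 2 of the 3 values shown sit, so it gives no size. Compound 4 `COC(=O)c1ccc(NCc2cncn2Cc2cccc([N+](=O)[O-])c2)cc1-c1ccccc1` differs from compound 3 in one place: 3-nitrophenyl in place of 4-bromophenyl on a saturated chain carbon bound to an aromatic nitrogen. Among the measured compounds shown here, no measured step speaks to a 3-nitrophenyl here. Compound 4 is therefore expected to stay at the limit, with an estimated 15000 nM spanning 7000 nM to 40000 nM. The expected step, a step that the limit leaves unreadable from compound 3 to compound 4, is none beyond the scatter.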

Compound 4, half-maximal effective concentration: > 10000 nM
Compound 4 ended at the assay's limit; the forecaster's own chance of this, stated with the estimate: 80%; the middle value is on the limit's open side.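

No step can be read from compound 3 to compound 4 or from compound 2 to compound 4, since all three compounds stand at a limit of the assay: the limit of > 10000 nM in this assay, at which 3 of the 4 values shown sit.

Going by these compounds, how much compound each of the three would need in this assay, and whether 3-nitrophenyl differs from 4-bromophenyl there, stays open.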